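The source may hold more compounds than are shown below. What is called first, only, known or untested is meant among the compounds shown, and "the series" means these compounds.

In an ADME assay on microsomes from liver (Homo sapiens) for metabolic stability, read by LC-MS, with NADPH named in the record, with a stated time of 60 min, tested at 1 uM, in the absence of a further agent (on this read-out lower numbers stand for a less stable compound and higher numbers for a more stable compound), compound 1 (`COc1ccc(-c2c(C)nc3c(N4CC[C@@H](NC(C)=O)C4)cc(C)nn23)cc1OC`) gives > 95%, which is a limit of the assay and not a number. Compound 2 (`COc1ccc(-c2c(C)nc3c(N4CC[C@@H](NC(=O)C(F)(F)F)C4)cc(C)nn23)cc1OC`) gives > 95%, likewise only a limit. Compound 3 (`CCCCCC(=O)N[C@@H]1CCN(c2cc(C)nn3c(-c4ccc(OC)c(OC)c4)c(C)nc23)C1`) carries pentyl in place of trifluoromethyl on a carbonyl carbon. Among the compounds with values here, the one measured step that bears on this change is a step that the two limits leave unreadable from compound 1 to compound 2, with trifluoromethyl in place of methyl on a carbonyl carbon. It gives no size to carry over, as both values rest on (the limit of > 95% in this assay, at which 2 of the 2 values shown sit). Within the data shown here, no measured compound carries pentyl. Starting from a limit, a readable change in this assay could only run toward a less stable compound. A moderate fall is therefore expected, a number at least 17 percentage points lower from compound 2 to compound 3 (beyond the scatter). The estimated value for compound 3 is 78%, with an expected range from 50% to 98%.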

Compound 3, percent of the compound remaining: > 95%
Compound 3: only a limit was reported; the forecaster's own chance of this, stated with the estimate: 30%; middle value at least 17 percentage points away from the limit.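

Within the data shown here, no step among compound 1, compound 2 and compound 3 can be read in this assay, since all three rest on the same limit of the assay: the limit of > 95% in this assay, at which 3 of the 3 values shown sit. The compounds shown leave open whether methyl, trifluoromethyl and pentyl on the carbonyl carbon differ at all in this read-out.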